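Shorter chain on the second core: expected pannexin-1 inhibition

The source may hold more compounds than are shown below. What is called first, only, known or untested is meant among the compounds shown, and "the series" means these compounds.

Compound 1 `O=C(O)c1cn(CCCCc2ccccc2)c2ccc([N+](=O)[O-])cc12` and compound 2 `O=C(O)c1cn(CCCCCc2ccccc2)c2ccc([N+](=O)[O-])cc12` share one core and differ only in the chain on the aromatic nitrogen. In an assay on cells (Oocyte) for inhibition of pannexin-1 (Mus musculus), read by voltage clamp, tested at 50 uM, in the presence of a further agent that is not named here (on this read-out higher numbers stand for more inhibition at the one concentration tested (going by the name of the read-out) and lower numbers for less inhibition), compound 1 gives 65.7%, while compound 2 gives 32.3%. The change from compound 2 to compound 1 is phenyl in place of benzyl on a saturated chain carbon, four bonds along the chain from an aromatic nitrogen and makes a step of a number 33.4 percentage points higher from compound 2 to compound 1 (beyond the scatter).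

Compound 3 `O=C(O)c1cc2cc([N+](=O)[O-])ccc2n1CCCCCc1ccccc1` carries the same atoms as compound 2 joined differently; the difference between the two cores is not broken down here. In this assay compound 3 gives 58%, which stands against compound 2 beyond the scatter and against compound 1 within it.

Compound 4 `O=C(O)c1cc2cc([N+](=O)[O-])ccc2n1CCCCc1ccccc1` is not yet measured. It differs from compound 3 by phenyl in place of benzyl on a saturated chain carbon, four bonds along the chain from an aromatic nitrogen, the same change as that from compound 2 to compound 1, at the same place by the words given for both.

Among the compounds with values here, only one measured example of this change exists, so its size on the core of compound 3 is uncertain, and compound 3 already sits high, leaving less room upward. A step of about a number 20 percentage points higher from compound 3 to compound 4 (beyond the scatter) is expected for compound 4, resting on the step from compound 2 to compound 1 of a number 33.4 percentage points higher from compound 2 to compound 1 (beyond the scatter). Compound 4 is therefore expected to give about 78% in this assay. The expected range for compound 4 runs from 58% to 95%.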

Compound 4, a percentage reported as inhibition, at one concentration (the size of the read-out at that concentration, not a potency): "not active" (no number reported)
For compound 4 the study gives words and no number; no gap can be computed for the estimate.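

Within the data shown here, compound 4 is reported in words only, as "not active", so no step from compound 3 to compound 4 can be read in this assay. No measured evidence available here bears on this result. The compounds shown leave open whether phenyl in place of benzyl at this chain position shifts inhibition in the same direction on the core of compound 3 as on the core of compound 2.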